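Compound 4: hydrogen in place of fluoro

A few compounds are considered here, and "the series" means these few. Any claim that something is new, unique, unknown or untested is made for them only; others in the source may bear on it.

In a functional assay on A549 cells (Homo sapiens) for antiproliferative activity, read by MTT assay, with a stated time of 72 h (on this read-out lower numbers stand for stronger inhibition and higher numbers for weaker inhibition), compound 1 `O=C(N/N=C/c1ccc([N+](=O)[O-])cc1)Nc1ccc(Oc2ccnc3[nH]ccc23)c(F)c1` reads 20 nM while compound 2 `O=C(N/N=C/c1ccc(O)cc1)Nc1ccc(Oc2ccnc3[nH]ccc23)c(F)c1` reads 3760 nM and compound 3 `O=C(N/N=C/c1ccc(O)c(Br)c1)Nc1ccc(Oc2ccnc3[nH]ccc23)c(F)c1` reads 9250 nM on the same core. Compound 2 therefore holds the second highest of the three numbers, far above compound 1 and modestly below compound 3.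

The next analogue is compound 4 `O=C(N/N=C/c1ccc(O)cc1)Nc1ccc(Oc2ccnc3[nH]ccc23)cc1` with the change hydrogen in place of fluoro on an aromatic carbon. Among the measured compounds shown here, no measured step touches the fluoro, as all three compounds carry it. The two large steps, a 190-fold higher number from compound 1 to compound 2 (2.27 log units; beyond the scatter) and a 460-fold higher number from compound 1 to compound 3 (2.67 log units; beyond the scatter), both replace the nitro-bearing aryl group and say little about this change. Bromo in place of hydrogen on an aromatic carbon gave a 2.5-fold higher number from compound 2 to compound 3 (0.39 log units; beyond the scatter) and that modest size, on a different aromatic ring, is the nearest guide available. For the measured compounds named here, it is the only halogen step and it points only weakly to a direction for the loss of a halogen here.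

No step beyond the scatter is therefore expected in this assay in either direction. The expected step is a 1.1-fold higher number from compound 2 to compound 4 (0.03 log units; within the scatter) and the uncertainty on it remains wide. Compound 4 is estimated at 4000 nM with 1500 nM to 10000 nM as the expected range.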

Compound 4, half-maximal inhibitory concentration: 1910 nM
Beside the measured number, compound 4's estimate is 2.1-fold (0.32 log units) above it; low and high end bracket the measured number.
By their numbers in this assay, from the lowest: compound 1; then compounds 4 and 2 (each within the scatter of the next); then compound 3.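

In this assay, among the compounds shown here, hydrogen in place of fluoro gives a 2.0-fold lower number from compound 2 to compound 4 (0.29 log units; within the scatter), the first reading at this carbon, which is ortho to a large group and meta to a large group on a six-membered aromatic ring of carbon only. With the 4-hydroxyphenyl group kept constant, the fluoro is therefore not needed to keep the read-out at the level of compound 2, and this single pair gives no evidence that the fluoro either helps or harms. No supporting measurement is available that would explain this outcome at the position.

The compounds shown leave open whether a chloro, methyl, methoxy or amino group at this carbon would move the number beyond the scatter, since only fluoro and hydrogen have been compared here. They also leave open whether hydrogen in place of fluoro would read the same way alongside the 4-nitrophenyl group of compound 1 or the 3-bromo-4-hydroxyphenyl group of compound 3, as the present comparison rests on the 4-hydroxyphenyl pair alone.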